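Cyclohexylmethoxy to cyclopentylmethoxy: working notes on the series

The compounds below may be only part of what the source reports. "The series", "measured", "known", "first", "only" and "open" are said of these compounds alone.

Measured in a functional assay on NUGC-3 cells (Homo sapiens) for antiproliferative activity, read by sulforhodamine B assay; on this read-out higher numbers stand for weaker inhibition of growth and lower numbers for stronger inhibition of growth:
- compound 1 `CCCCCCOc1cccc(O)c1C(=O)/C=C/c1ccc(O)cc1` gives > 30000 nM (a limit)
- compound 2 `CC(C)(C)CCOc1cccc(O)c1C(=O)/C=C/c1ccc(O)cc1` gives 3300 nM
- compound 3 `O=C(/C=C/c1ccc(O)cc1)c1c(O)cccc1OCC1CCCCC1` gives > 30000 nM (a limit)

Compound 3 has only a limit and no number, and it stands at the limit of > 30000 nM in this assay, at which 2 of the 3 values shown sit.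

The next structure is compound 4 `O=C(/C=C/c1ccc(O)cc1)c1c(O)cccc1OCC1CCCC1`, and the change is cyclopentyl in place of cyclohexyl on a saturated chain carbon bound to an oxygen on an aromatic ring. This places cyclopentyl in place of cyclohexyl on a saturated chain carbon bound to an oxygen on an aromatic ring.

Among the measured compounds shown here, no measured step makes this exact exchange. The nearest is cyclohexyl in place of neopentyl, which gave an at least 9.0-fold higher number from compound 2 to compound 3 (0.95 log units; beyond the scatter). Tert-butyl in place of butyl gave an at least 9.0-fold lower number from compound 1 to compound 2 (0.95 log units; beyond the scatter). The comparison of the two limits gives a step that the two limits leave unreadable from compound 1 to compound 3. The side chain can therefore matter, but only compound 2 gives a number, at 3300 nM.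

A small move toward lower numbers in this assay is expected, and a limit reading is about as likely as a number. The expected change is an at least 1.5-fold lower number from compound 3 to compound 4 (0.17 log units; that floor lies within the scatter).

The estimate for compound 4 is 20000 nM, with an expected range of 6000 nM to 60000 nM.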

Compound 4, concentration for 50% growth inhibition: 2140 nM
Beside the measured number, compound 4's estimate is 9.3-fold (0.97 log units) above it; the measured number lies below the stated range.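

In this assay, the ring size on the saturated chain carbon bound to an oxygen on an aromatic ring matters sharply: cyclopentyl in place of cyclohexyl gives an at least 14-fold lower number from compound 3 to compound 4 (1.14 log units; beyond the scatter). Cyclopentyl in place of neopentyl gives a 1.5-fold lower number from compound 2 to compound 4 (0.19 log units; within the scatter), so two quite different side chains read alike, and a number is not confined to the branched chain of compound 2. Cyclopentyl in place of pentyl gives an at least 14-fold lower number from compound 1 to compound 4 (1.14 log units; beyond the scatter), and this step and the one from cyclohexyl each start from a limit and not a number: the limit of > 30000 nM in this assay, at which 2 of the 4 values shown sit.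

As far as these compounds go, how far compound 1 and compound 3 lie past their limits remains open, so the true size of both large steps is unknown. Also open, from the compounds shown here alone, is how a cyclobutyl ring, or an amine in the side chain, would read at this position.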